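This account rests on a few compounds, and the source may have more. Where it says the series, first, only, none or still open, it means among the compounds named here.

Measured so far:
compound 1 `COC(=O)c1c(NCc2ccc(C(C)(C)C)cc2)noc1-c1ccc([N+](=O)[O-])cc1`: 81400 nM
compound 2 `COC(=O)c1c(NCc2ccc(OC)c(OC)c2)noc1-c1ccc([N+](=O)[O-])cc1`: "not determined" (no result reported)
compound 3 `COC(=O)c1c(NCc2ccc(OC)cc2OC)noc1-c1ccc([N+](=O)[O-])cc1`: "not determined" (no result reported)

These entries come from an ADME assay on J774.A1 cells (Mus musculus) for cytotoxicity, read by MTT assay, with a stated time of 48 h; a higher number here means that more compound is tolerated, a lower number that less compound is tolerated. Only compound 1 has a number, so this small series offers no scale on which to rank the others. Compound 3 has no single value to place, and compound 2 is in the same position.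

The next compound to be tested is compound 4 `COC(=O)c1c(NCc2ccc(OC)cc2OC)noc1-c1ccc(Cl)cc1Cl`, which has not yet been measured. The structural change is 2,4-dichlorophenyl in place of 4-nitrophenyl on an aromatic carbon. In words, 2,4-dichlorophenyl takes the place of 4-nitrophenyl on an aromatic carbon, next to the ring oxygen.

With no number for compound 3, this change has no measured starting point. For the measured compounds named here, no pair of measured compounds shows what a change at this place does in this assay either. The data therefore support no expected direction, and the expected step is none beyond the scatter. Going by the values given here, the only available anchor is compound 1 at 81400 nM, although it also differs from compound 4 elsewhere in the structure, so the range must stay wide. Compound 4 is expected at about 60000 nM, with an estimated range from 20000 nM to 160000 nM.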

Compound 4, half-maximal cytotoxic concentration: 32200 nM
Compound 4: middle estimate off by 1.9-fold (0.27 log units), on the high side; measured number inside the range.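

No step can be read between compound 3 and compound 4: in this assay, only compound 4 has a single number. As far as these compounds go, what 2,4-dichlorophenyl in place of 4-nitrophenyl does to the tolerated concentration therefore stays open. Nothing measured here offers an explanation for the value of compound 4.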